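Acetonide Removal on a Triazole-Linked Series

The compounds below may be only part of what the source reports. "The series", "measured", "known", "first", "only" and "open" are said of these compounds alone.

Compound 1 `O=C1c2c[n+]([O-])c3ccccc3c2C(=O)c2c1c1ccccc1n2CCCCn1ccnc1`: 150 nM
Compound 2 `CC1(C)OC[C@H](Cn2cc(Cn3c4c(c5ccccc53)C(=O)c3c[n+]([O-])c5ccccc5c3C4=O)nn2)O1`: 470 nM

Of the compounds shown here, two on the shared core have been measured in a toxicity assay on L02 cells (Homo sapiens) for cytotoxicity, read by MTT assay, with a stated time of 72 h; on this read-out lower numbers stand for stronger inhibition and higher numbers for weaker inhibition. Compound 1 gives 150 nM. Compound 2 gives 470 nM, the highest of the two numbers, and its gap to compound 1 lies beyond the scatter. Compound 3 `O=C1c2c[n+]([O-])c3ccccc3c2C(=O)c2c1c1ccccc1n2Cc1cn(C[C@@H](O)CO)nn1` differs from compound 2 in one place: 1,2-dihydroxyethyl in place of 2,2-dimethyl-1,3-dioxolan-4-yl on a saturated chain carbon bound to an aromatic nitrogen. Going by the values given here, no measured pair shows this change, so the direction is open. A step no larger than the scatter is expected, a 1.3-fold higher number from compound 2 to compound 3 (0.11 log units; within the scatter), and compound 3 is estimated at 600 nM, within 250 nM to 1500 nM.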

Compound 3, half-maximal inhibitory concentration: 490 nM
Estimate against measurement, compound 3: 1.2-fold (0.09 log units) above; the measured number falls inside the stated range.
By their numbers in this assay, from the lowest: compound 1; then compounds 2 and 3 (each within the scatter of the next).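

In this assay, replacing 2,2-dimethyl-1,3-dioxolan-4-yl with 1,2-dihydroxyethyl on a saturated chain carbon bound to an aromatic nitrogen gives a 1.0-fold higher number from compound 2 to compound 3 (0.02 log units; within the scatter) and so does not separate the two compounds, although the ring is lost and hydrogen-bond donors enter. The clear gap lies with the larger replacement, a 3.3-fold higher number from compound 1 to compound 3 (0.51 log units; beyond the scatter) when 1-(2,3-dihydroxypropyl)-1H-1,2,3-triazol-4-yl stands in place of 3-(1H-imidazol-1-yl)propyl. Going by these compounds, whether an amine or a carboxylic acid in place of 1,2-dihydroxyethyl would separate from compound 3 stays open. No measurement shown here accounts for either step.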